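Replacing the 3-hydroxyphenyl group of compound 2

The source may report more compounds than this note shows. Statements on the series, on what has been measured and on what is new or still open speak of the compounds shown alone.

Measured in a functional assay on A549 cells (Homo sapiens) for antiproliferative activity, read by MTT assay, with a stated time of 72 h; on this read-out higher numbers stand for weaker inhibition and lower numbers for stronger inhibition:
- compound 1 `COc1cc(-n2cnc3ccc(-c4ccccc4Cl)cc32)cc(OC)c1OC`: > 10000 nM (a limit)
- compound 2 `COc1cc(-n2cnc3ccc(-c4cccc(O)c4)cc32)cc(OC)c1OC`: 250 nM

Among the compounds with values here, compound 2, at 250 nM, holds the only true number in this assay. Compound 1 gives > 10000 nM, which is a limit of the assay and not a number. The next structure is compound 3 `COc1cc(-n2cnc3ccc(-c4cccc(C)c4C)cc32)cc(OC)c1OC`, with 2,3-dimethylphenyl in place of 3-hydroxyphenyl on an aromatic carbon. Within the data shown here, one measured step bears on this change, at the same place on the shared core: an at least 40-fold lower number from compound 1 to compound 2 (1.60 log units; beyond the scatter), which is large. Compound 3 also gives up the 3-hydroxyphenyl group, so a higher number is expected in this assay, though probably a smaller change than that single step, which offers thin support. The expected change is a 10-fold higher number from compound 2 to compound 3 (1.00 log units; beyond the scatter). For compound 3 the estimated value is 2500 nM, with an expected range of 400 nM to 10000 nM.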

Compound 3, half-maximal inhibitory concentration: 9250 nM
Beside the measured number, compound 3's estimate is 3.7-fold (0.57 log units) below it, and the stated range covers the measured number.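

In this assay, 2,3-dimethylphenyl in place of 3-hydroxyphenyl gives a 37-fold higher number from compound 2 to compound 3 (1.57 log units; beyond the scatter) and so extends what 2-chlorophenyl suggested: a second replacement without the hydroxy group also stands far from compound 2 at this position. Compound 3 still gives a true number, so a value can be read at this position without the 3-hydroxyphenyl group. The remaining step of an at least 1.0-fold lower number from compound 1 to compound 3 (0.03 log units; that floor lies within the scatter) cannot be read as a difference, since one end of it is a limit of the assay and not a number: the limit of > 10000 nM in this assay, at which 1 of the 3 values shown sits.

Whether the hydroxy group itself carries the gain stays open, as 3-hydroxyphenyl is the only such group among these compounds. A 3-methoxyphenyl or 3-aminophenyl group would test that, and a 3-methylphenyl group would separate the two methyl groups of compound 3.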